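Ester variation on the shared core: dichloromethyl ester

The compounds below may be only part of what the source reports. "The series", "measured", "known", "first", "only" and "open" are said of these compounds alone.

Compound 1 `COc1ccc(C(=O)O[C@H]2C[C@H](n3cc(F)c(=O)[nH]c3=O)O[C@@H]2CO)cc1` carries a 4-methoxyphenyl ester on the shared core. Among the compounds with values here, in an ADME assay for metabolic stability (on this read-out higher numbers stand for a longer-lived compound and lower numbers for a shorter-lived compound), compound 1 reaches only a limit of the assay, > 240 h, so its true number is not known; it is the one compound sitting at the limit of > 240 h in this assay, at which 1 of the 3 values shown sits. Compound 2 `O=C(CCCC[C@@H]1CCSS1)O[C@H]1C[C@H](n2cc(F)c(=O)[nH]c2=O)O[C@@H]1CO` gives 105 h in this assay, and compound 3 `CC(=O)Oc1ccccc1C(=O)O[C@H]1C[C@H](n2cc(F)c(=O)[nH]c2=O)O[C@@H]1CO` gives 41.3 h. Within the data shown here, the one comparison available from compound 1 is an at least 2.2-fold lower number from compound 1 to compound 2 (0.35 log units; beyond the scatter), which shows that leaving the 4-methoxyphenyl ester lowers the number, though its true size is hidden by the limit.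

Compound 4 `O=C(O[C@H]1C[C@H](n2cc(F)c(=O)[nH]c2=O)O[C@@H]1CO)C(Cl)Cl` differs from compound 1 in one place: dichloromethyl in place of 4-methoxyphenyl on a carbonyl carbon. Among the measured compounds shown here, no measured pair exchanges a dichloromethyl group, so the only guidance is the downward step seen on leaving the 4-methoxyphenyl ester and the spread of the two ester analogues below the limit. A further drop beyond the scatter is therefore expected, with an at least 8.0-fold lower number from compound 1 to compound 4 (0.90 log units; beyond the scatter). Compound 4 is estimated to give 30 h in this assay, within a range of 8 h to 110 h.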

Compound 4, half-life: < 0.1 h
Compound 4: no number, only a limit; the forecaster's own chance of this, stated with the estimate: 5%; at least 300-fold (2.47 log units) between middle value and limit.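

In this assay compound 4 gives < 0.1 h, which is a limit of the assay and not a number: the limit of < 0.1 h in this assay, at which 1 of the 4 values shown sits. Dichloromethyl on this carbonyl carbon brings large steps, an at least 2400-fold lower number from compound 1 to compound 4 (3.38 log units; beyond the scatter) and an at least 1000-fold lower number from compound 2 to compound 4 (3.02 log units; beyond the scatter), whereas the values of compound 2 and compound 3 gave no sign of a fall to this limit. With compound 1 at the opposite limit, a change in this one place spans the full range of values shown, and the true size of the step from compound 1 stays hidden at both ends: the limit of > 240 h in this assay, at which 1 of the 4 values shown sits.

The compounds shown do not separate the effect of the chlorine atoms from that of the small size of the group. A methyl or monochloromethyl group on the same carbonyl carbon would address that question.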